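Removing the thioether from a weakly active pyrazole analogue

The source may hold more compounds than are shown below. What is called first, only, known or untested is meant among the compounds shown, and "the series" means these compounds.

The study compares pyrazole-bearing compounds on a shared core tested in a functional assay on MCF7 cells (Homo sapiens) for inhibition, read by MTT assay, with a stated time of 72 h; on this read-out higher numbers stand for weaker inhibition and lower numbers for stronger inhibition. Compound 1 `Cc1cc(Nc2ccn(Cc3cccc4ccccc34)n2)n2nc(SCc3ccc(Br)cc3)nc2n1` gives 4310 nM, and compound 3 `COc1ccc(Cn2ccc(Nc3cc(C)nc4nc(SCc5ccc(Br)cc5)nn34)n2)cc1` gives 14600 nM; the change of 4-methoxyphenyl in place of naphthalen-1-yl on a saturated chain carbon bound to an aromatic nitrogen gives a 3.4-fold higher number from compound 1 to compound 3 (0.53 log units; beyond the scatter). Compound 2 `Cc1cc(Nc2cc(-c3ccccc3)[nH]n2)n2nc(SCC3CCCCC3)nc2n1` is reported only as a limit, > 50000 nM, and so stands at the limit of > 50000 nM in this assay, at which 1 of the 3 values shown sits, rather than at a measured number. Compound 4 `Cc1cc(Nc2cc(-c3ccccc3)[nH]n2)n2ncnc2n1` has not yet been measured. It differs from compound 2 by hydrogen in place of (cyclohexylmethyl)sulfanyl on an aromatic carbon. Among the measured compounds shown here, no measured step touches this position: the one measured step concerns a different part of the molecule, so it gives no direct guide. The starting point for compound 4 is itself a limit, so any expectation stays rough. Compound 4 is expected to sit near the same limit, an estimated 60000 nM with a range of 15000 nM to 200000 nM, because compound 2 already gives > 50000 nM. The expected change is a step that the limit leaves unreadable from compound 2 to compound 4, likely not beyond the scatter.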

Compound 4, half-maximal inhibitory concentration: > 50000 nM
Compound 4: a limit, no number; the forecaster's own chance of this, stated with the estimate: 70%; the middle value lies beyond the limit too.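

In this assay compound 4 gives > 50000 nM, which is a limit and not a number. Compound 2 is also a limit, and no step from compound 2 to compound 4 can be read: the limit of > 50000 nM in this assay, at which 2 of the 4 values shown sit.

The compounds shown leave open whether hydrogen in place of (cyclohexylmethyl)sulfanyl changes the read-out at all.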